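Branching the ethylamine: from ethyl to isopropyl

The source may hold more compounds than are shown below. What is called first, only, known or untested is meant among the compounds shown, and "the series" means these compounds.

compound 1, `CN(CC(=O)Nc1nc2ccc(OC(F)(F)F)cc2s1)C(=O)CN`: a limit of the assay, < 0.1 h in an ADME assay on a cell-free system (serum, Rattus norvegicus) for pharmacokinetics; a lower number here means that the compound disappears faster, a higher number that the compound lasts longer
compound 2, `CNCC(=O)N(C)CC(=O)Nc1nc2ccc(OC(F)(F)F)cc2s1`: a limit of the assay, < 0.1 h
compound 3, `CCNCC(=O)N(C)CC(=O)Nc1nc2ccc(OC(F)(F)F)cc2s1`: a limit of the assay, < 0.25 h
compound 4, `CC(C)NCC(=O)N(C)CC(=O)Nc1nc2ccc(OC(F)(F)F)cc2s1`: not yet measured

Compound 3 stands at a limit of the assay, < 0.25 h, and the other two measured values are limits as well. The steps a step that the two limits leave unreadable from compound 1 to compound 2, a step that the two limits leave unreadable from compound 1 to compound 3 and a step that the two limits leave unreadable from compound 2 to compound 3 therefore cannot be sized: the limit of < 0.1 h in this assay, at which 2 of the 3 values shown sit, and the limit of < 0.25 h in this assay, at which 1 of the 3 values shown sits, mark where the assay stops reporting a number. Compound 4 differs from compound 3 by methyl in place of hydrogen on a saturated chain carbon bound to an amine nitrogen and a saturated chain carbon. The nearest measured step, a step that the two limits leave unreadable from compound 2 to compound 3, is unreadable, so no direction is supported. Compound 4 is expected to stay near the limits, an estimated step that the limit leaves unreadable from compound 3 to compound 4. The estimate for compound 4 is 0.2 h, in a range from 0.05 h to 0.8 h.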

Compound 4, half-life: > 2 h
Compound 4: no number, only a limit; the forecaster's own chance of this, stated with the estimate: 60%; middle value at least 10-fold (1.00 log units) away from the limit.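

In this assay compound 4 gives > 2 h, which is a limit of the assay. Going by these compounds alone, this change yields the first readable steps: adding one methyl to the saturated chain carbon, turning ethyl into isopropyl, gives an at least 8.0-fold higher number from compound 3 to compound 4 (0.90 log units; beyond the scatter). On the amine nitrogen, isopropyl in place of methyl gives an at least 20-fold higher number from compound 2 to compound 4 (1.30 log units; beyond the scatter), and isopropyl in place of hydrogen gives an at least 20-fold higher number from compound 1 to compound 4 (1.30 log units; beyond the scatter). From the compounds shown here alone, the actual half-life of compound 4 remains open, as its limit gives no upper end. Also open, going by these compounds, is whether a cyclopropyl or tert-butyl group on the same amine nitrogen would behave like isopropyl.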